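Swapping a Piperidine for a Lactam on a Shared Core

The source may hold more compounds than are shown below. What is called first, only, known or untested is meant among the compounds shown, and "the series" means these compounds.

Two compounds of this series have numbers in an assay for inhibition of inositol hexakisphosphate kinase 3 (Homo sapiens), read by colorimetric assay, coupled enzyme assay and malachite green, with a stated time of 120 min, in the presence of a further agent that is not named here; a lower number here means a stronger inhibitor, a higher number a weaker inhibitor. Compound 1 `O=C(O)/C=C/c1ccc2noc(-c3ccc(-c4ccccc4)cc3)c2c1` gives 200 nM in this assay. Compound 2 `O=C(O)c1ccc2noc(-c3ccc(N4CCCCC4)cc3)c2c1` gives 1790 nM in this assay, the higher of the two numbers, and its gap to compound 1 lies beyond the scatter. Compound 3 `O=C(O)c1ccc2noc(-c3ccc(N4CCCC4=O)cc3)c2c1` has not yet been measured. It differs from compound 2 in one place: 2-oxopyrrolidin-1-yl in place of piperidin-1-yl on an aromatic carbon. Among the measured compounds shown here, no measured pair in the set carries this same change, so its effect cannot be read from the data at hand. The step from compound 2 to compound 3 in this assay is expected to be small, within or only just beyond the scatter, and if anything upward, as a 1.4-fold higher number from compound 2 to compound 3 (0.15 log units; within the scatter). Compound 3 is accordingly estimated at 2500 nM in this assay, with a range from 800 nM to 8000 nM.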

Compound 3, half-maximal inhibitory concentration: 2170 nM
Beside the measured number, compound 3's estimate is 1.2-fold (0.06 log units) above it; the range from low to high includes it.
By their numbers in this assay, from the lowest: compound 1; then compounds 2 and 3 (each within the scatter of the next).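

In this assay, 2-oxopyrrolidin-1-yl in place of piperidin-1-yl on an aromatic carbon, para to a large group, gives a 1.2-fold higher number from compound 2 to compound 3 (0.08 log units; within the scatter). Among the compounds shown here, this is the first single-place pair in the set, and it shows that this assay does not tell these two groups apart at this position, even though one is a six-membered ring and the other a five-membered ring carrying a carbonyl. Nothing at hand bears on the reason for this result.

On these data alone, it remains open whether a group of a different kind on this aromatic carbon, such as a primary amine or a morpholine ring, would separate from these two in this assay. Also open, as far as these compounds go, is whether the same exchange would read alike on a core with a longer chain carrying the carboxylic acid, as in compound 1.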